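The compounds below may be only part of what the source reports. "The series", "measured", "known", "first", "only" and "open" are said of these compounds alone.

Measured so far in a functional assay on OVCAR-3 cells (Homo sapiens) for cytotoxicity, read by sulforhodamine B assay; a lower number here means a stronger inhibitor of growth, a higher number a weaker inhibitor of growth:
- compound 1 `COc1ccc(/C=N\NC(=S)NC(C)(C)CCC[C@](C)(O)[C@@H]2CC=C(C)CC2)cc1`: 15800 nM
- compound 2 `CC1=CC[C@@H]([C@@](C)(O)CCCC(C)(C)NC(=S)N/N=C\c2ccc([N+](=O)[O-])cc2)CC1`: 88600 nM

Compound 2 has the higher of the two numbers, so it is the weaker growth inhibitor of this pair in this assay. Compound 3 `CC1=CC[C@@H]([C@@](C)(O)CCCC(C)(C)NC(=S)N/N=C\c2cccc(Cl)c2)CC1` is the next to be read against it. The change is 3-chlorophenyl in place of 4-nitrophenyl on a carbon with a double bond to nitrogen, with 3-chlorophenyl in place of 4-nitrophenyl on a carbon with a double bond to nitrogen.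

Going by the values given here, only one measured step bears on this, and only in part: a 5.6-fold higher number from compound 1 to compound 2 (0.75 log units; beyond the scatter), which is modest and came with nitro in place of methoxy on an aromatic carbon. Among the compounds with values here, compound 3 also lacks the nitro group, but no measured compound carries chlorine, so the data give no direct measure of its contribution. A modest step towards a lower number in this assay is therefore expected, probably no larger than the measured one, with wide uncertainty. The expected change is a 2.5-fold lower number from compound 2 to compound 3 (0.40 log units; beyond the scatter). For compound 3 the estimate is 35000 nM, with an expected range of 12000 nM to 100000 nM.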

Compound 3, concentration for total growth inhibition: 26500 nM
For compound 3 the middle estimate is 1.3-fold (0.12 log units) above the measured one; the measured number falls inside the stated range.
By their numbers in this assay, from the lowest: compounds 1 and 3 (each within the scatter of the next); then compound 2.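

Setting 3-chlorophenyl in place of 4-nitrophenyl on a carbon with a double bond to nitrogen gives, in this assay, a 3.3-fold lower number from compound 2 to compound 3 (0.52 log units; beyond the scatter), so the high number of compound 2 does not extend to this second replacement at the same place. Against the 4-methoxyphenyl group, the same 3-chlorophenyl group gives a 1.7-fold higher number from compound 1 to compound 3 (0.22 log units; within the scatter), which lies within the scatter; compound 1 and compound 3 therefore cannot be ordered, and among the three only compound 2 stands apart, as the weakest growth inhibitor. No evidence is at hand on what lies behind these differences.

The compounds shown change the substituent and its printed ring position together, since 3-chlorophenyl is being read against two 4-substituted phenyl groups, so the contribution of chlorine cannot be separated from that of its position on the phenyl ring. Still open, from the compounds shown here alone, is how a 4-chlorophenyl or an unsubstituted phenyl group would read at this place, and whether an aryl group carrying an amine or a carboxylic acid would stay with compound 1 and compound 3 or move towards compound 2.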